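A few compounds are considered here, and "the series" means these few. Any claim that something is new, unique, unknown or untested is made for them only; others in the source may bear on it.

Measured in a functional assay on KB cells (Homo sapiens) for antiproliferative activity, with a stated time of 72 h; a lower number here means a stronger inhibitor, a higher number a weaker inhibitor:
- Compound 1 `C=C1C=CC(=O)[C@@H]2[C@H](Cc3ccc(OCOC)cc3)CC[C@H]12`: 208 nM
- Compound 2 `C=C1C=CC(=O)[C@@H]2[C@H](Cc3ccc(OCOC)c(F)c3)CC[C@H]12`: 76.6 nM

Compound 2 has the lower of these two numbers, making it the stronger inhibitor so far. Compound 3 `C=C1C=CC(=O)[C@@H]2[C@H](Cc3ccc(F)c(F)c3)CC[C@H]12` differs from it by one change: fluoro in place of methoxymethoxy on an aromatic carbon. Among the compounds with values here, only one measured step bears on this, and only loosely: a 2.7-fold lower number from compound 1 to compound 2 (0.43 log units; beyond the scatter), a modest gain from fluoro in place of hydrogen. Within the data shown here, no measured compound shows what losing methoxymethoxy does, so the direction is uncertain. A modest loss in this assay is expected, and the estimated step is a 2.0-fold higher number from compound 2 to compound 3 (0.29 log units; within the scatter). Compound 3 is estimated at 150 nM, with an expected range of 40 nM to 550 nM.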

Compound 3, half-maximal inhibitory concentration: 478 nM
For compound 3 the middle estimate is 3.2-fold (0.50 log units) below the measured one; the range from low to high includes it.
By their numbers in this assay, from the lowest: compound 2; then compound 1; then compound 3.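

Within the data shown here, the earlier compounds all kept methoxymethoxy, so this is the first view of what that position contributes. In this assay, fluoro in its place gives a weaker inhibitor (a 6.2-fold higher number from compound 2 to compound 3 (0.80 log units; beyond the scatter)), so this position, ortho to a fluoro group, is sensitive to the change. No available evidence explains this loss.

The change removes both heavy atoms and hydrogen-bond acceptors, and these compounds cannot separate the two. A plain methoxy or a hydroxy group at this position would show how much of methoxymethoxy is needed.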